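One Substituent Change Between Compound 2 and Compound 4

The source may report more compounds than this note shows. Statements on the series, on what has been measured and on what is new or still open speak of the compounds shown alone.

Of the compounds shown here, three sharing one core have been measured in an ADME assay for permeability, using PAMPA, at pH 7.4; a higher number here means that the compound crosses the layer faster, a lower number that the compound crosses the layer more slowly. Compound 1 `Cc1cc(NC(=O)Nc2ncccc2C)c2ccccc2n1` gives 369 10^-6 cm/s in this assay. Compound 2 `COC(=O)c1ccc(NC(=O)Nc2cc(C)nc3ccccc23)cc1` gives 448 10^-6 cm/s in this assay, the highest of the three numbers, though the gap to compound 1 lies within the scatter of repeated measurements. Compound 3 `Cc1cc(NC(=O)Nc2cccc([N+](=O)[O-])c2)c2ccccc2n1` gives 42 10^-6 cm/s in this assay, which falls clearly beyond the scatter below compound 2.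

Compound 4 `CCc1ccc(NC(=O)Nc2cc(C)nc3ccccc23)cc1` is not yet measured. It differs from compound 2 in one place: ethyl in place of methoxycarbonyl on an aromatic carbon. Among the measured compounds shown here, no measured pair in this set differs by exactly this change, so the expectation can rest only on the numbers above. Given that compound 2 already gives 448 10^-6 cm/s, compound 4 is expected to stay close to it, with the step of a 1.0-fold higher number from compound 2 to compound 4 (0.00 log units; within the scatter) estimated to lie within the scatter rather than beyond it. The estimate for compound 4 in this assay is therefore 450 10^-6 cm/s, with a likely range from 250 10^-6 cm/s to 800 10^-6 cm/s.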

Compound 4, apparent permeability: 535 10^-6 cm/s
Compound 4: middle estimate off by 1.2-fold (0.08 log units), on the low side; measured number inside the range.
By their numbers in this assay, from the lowest: compound 3; then compounds 1, 2 and 4 (each within the scatter of the next).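

At this aromatic carbon, para to a large group, the swap of methoxycarbonyl, with 4 heavy atoms and 2 hydrogen-bond acceptors, for ethyl, with 2 heavy atoms and 0 hydrogen-bond acceptors, gives a 1.2-fold higher number from compound 2 to compound 4 (0.08 log units; within the scatter) in this assay. Among the compounds shown here, this is the first single-place step in the set, and it shows that the read-out at this position tolerates this exchange of groups, with no change beyond the scatter. No measurement available here accounts for that outcome.

The step covers only these two groups at this one position, so a carboxylic acid, an amine or a longer chain there remains an open case. Whether ethyl in place of methoxycarbonyl would behave the same way on a different core also stays unanswered.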